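A Naphthyl Group Tested for Cell Tolerance

The compounds below may be only part of what the source reports. "The series", "measured", "known", "first", "only" and "open" are said of these compounds alone.

Compound 1 `Cc1cc(S(N)(=O)=O)ccc1NC(=O)COc1ccc(Cl)cc1C(O)c1ccccc1` was examined in an ADME assay on C8166 cells (Homo sapiens) for cytotoxicity, read by MTT assay (a higher number here means that more compound is tolerated, a lower number that less compound is tolerated), where compound 1 gives 33400 nM. Two relatives share its core. Compound 2 `Cc1cc(S(N)(=O)=O)ccc1NC(=O)COc1ccc(Cl)cc1C(O)c1cccc(Cl)c1` gives 33300 nM, and compound 3 `Cc1cc(S(N)(=O)=O)ccc1NC(=O)COc1ccc(Cl)cc1C(O)c1cc(Cl)ccc1Cl` gives 36200 nM. Among these three numbers compound 1 stands second highest, with the nearest being a 1.0-fold lower number from compound 1 to compound 2 (0.00 log units; within the scatter) and the furthest a 1.1-fold higher number from compound 1 to compound 3 (0.03 log units; within the scatter); the remaining step, a 1.1-fold higher number from compound 2 to compound 3 (0.04 log units; within the scatter), is also within the scatter.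

Compound 4 `Cc1cc(S(N)(=O)=O)ccc1NC(=O)COc1ccc(Cl)cc1C(O)c1cccc2ccccc12` is the next step from compound 1: naphthalen-1-yl in place of phenyl on a saturated chain carbon bound to an aromatic carbon and an oxygen on a saturated carbon. Among the measured compounds shown here, the steps that bear on it are those that alter the same phenyl group, namely a 1.0-fold lower number from compound 1 to compound 2 (0.00 log units; within the scatter) and a 1.1-fold higher number from compound 1 to compound 3 (0.03 log units; within the scatter). Neither moved the number beyond the scatter, even where a 2,5-dichlorophenyl entered. A naphthalen-1-yl group is a larger alteration than any measured here, so some uncertainty remains, but nothing measured points in either direction. Compound 4 is therefore expected to show a step of a 1.1-fold lower number from compound 1 to compound 4 (0.03 log units; within the scatter). In this assay compound 4 is estimated at 31000 nM, with a range from 15000 nM to 60000 nM.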

Compound 4, half-maximal cytotoxic concentration: 31100 nM
Beside the measured number, compound 4's estimate is 1.0-fold (0.00 log units) below it; the range from low to high includes it.
By their numbers in this assay, from the lowest: compounds 4, 2, 1 and 3 (each within the scatter of the next).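

Going from phenyl to naphthalen-1-yl raises the count from 6 to 10 heavy atoms and adds a second six-membered aromatic ring, yet the number in this assay stays within the scatter (a 1.1-fold lower number from compound 1 to compound 4 (0.03 log units; within the scatter)). Compared with the chlorinated relatives, the result is the same (a 1.1-fold lower number from compound 2 to compound 4 (0.03 log units; within the scatter); a 1.2-fold lower number from compound 3 to compound 4 (0.07 log units; within the scatter)), so at this position a second aromatic ring has no more visible effect here than chloro groups on the phenyl. No measurement shown explains why these numbers stay so close.

Going by these compounds, all the groups compared here at this position are aromatic rings of carbon, some carrying chloro, so it remains open whether an amine or a carboxylic acid on the ring would change the number. A longer chain in place of the ring is also untested among the compounds shown.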